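Amide chain series: from compound 3 to compound 4

The compounds below may be only part of what the source reports. "The series", "measured", "known", "first", "only" and "open" are said of these compounds alone.

Measured so far in a functional assay on A549 cells (Homo sapiens) for antiproliferative activity, read by CCK-8 assay, with a stated time of 72 h; a higher number here means a weaker inhibitor of growth, a lower number a stronger inhibitor of growth:
- compound 1 `CC[C@@H]1C(=O)N(C)c2cnc(-n3ccc4cc(C(=O)NC)ccc43)nc2N1C1CCCC1` gives 2200 nM
- compound 2 `CC[C@@H]1C(=O)N(C)c2cnc(-n3ccc4cc(C(=O)NC(C)C)ccc43)nc2N1C1CCCC1` gives 1780 nM
- compound 3 `CCCNC(=O)c1ccc2c(ccn2-c2ncc3c(n2)N(C2CCCC2)[C@H](CC)C(=O)N3C)c1` gives 1640 nM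

Compound 3 stands level with the other two: the data show a 1.3-fold lower number from compound 1 to compound 3 (0.13 log units; within the scatter) and also a 1.1-fold lower number from compound 2 to compound 3 (0.04 log units; within the scatter) here. Compound 4 `CC[C@@H]1C(=O)N(C)c2cnc(-n3ccc4cc(C(=O)NCC(C)C)ccc43)nc2N1C1CCCC1` follows with methyl in place of hydrogen on a saturated chain carbon bound to two saturated chain carbons and so turns propyl to isobutyl. The steps bearing on this all alter the chain on the amide-type nitrogen, and a 1.2-fold lower number from compound 1 to compound 2 (0.09 log units; within the scatter) stays small as well, so no step beyond the scatter is expected in this assay for this change. Compound 4 is estimated at 1600 nM (expected range 900 nM to 2800 nM). The estimated step is a 1.0-fold lower number from compound 3 to compound 4 (0.01 log units; within the scatter) and is expected to stay within the scatter.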

Compound 4, concentration for 50% growth inhibition: 1730 nM
Compound 4: middle estimate off by 1.1-fold (0.03 log units), on the low side, within the range that was stated.
By their numbers in this assay, from the lowest: compounds 3, 4, 2 and 1 (each within the scatter of the next).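

In this assay, the step from propyl to isobutyl on the amide-type nitrogen gives a 1.1-fold higher number from compound 3 to compound 4 (0.02 log units; within the scatter) and so adds nothing to the flat picture. Isopropyl to isobutyl gives a 1.0-fold lower number from compound 2 to compound 4 (0.01 log units; within the scatter) as well, and even the widest change here, from the methyl amide, gives a 1.3-fold lower number from compound 1 to compound 4 (0.10 log units; within the scatter) for this chain. Branching at this saturated chain carbon therefore leaves all four amides level, linear or branched.

Open, on these data alone, is whether a longer chain, or a chain ending in an amine or a carboxylic acid, would move the number beyond the scatter. No evidence is at hand to explain the flat response.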